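This account rests on a few compounds, and the source may have more. Where it says the series, first, only, none or still open, it means among the compounds named here.

Measured compounds in a functional assay on A549 cells (Homo sapiens) for antiproliferative activity, read by XTT assay, with a stated time of 72 h; a higher number here means a weaker inhibitor, a lower number a stronger inhibitor:
Compound 1, `C=C(C)CCC[C@]1(C)C2=CCC[C@](C)(C[C@@H](O)c3ccoc3)[C@H]2CC[C@H]1C`: compound 1 gives 66000 nM
Compound 2, `C=C(C)CC[C@]1(C)C2=CCC[C@](C)(C[C@@H](O)C3=CC(=O)OC3O)[C@H]2CC[C@H]1C`: compound 2 gives 4400 nM
Compound 3, `C=C(C)CCC[C@]1(C)C2=CCC[C@](C)(C[C@H](O)C3=CC(=O)OC3O)[C@H]2CC[C@H]1C`: compound 3 gives 3200 nM

Compound 3 has the lowest number of the three in this assay. Its nearest neighbour is compound 2, whose number sits within the scatter of it, so no order between those two can be claimed. For the measured compounds named here, its furthest neighbour is compound 1, and the one measured step that arrives at compound 3 is a 21-fold lower number from compound 1 to compound 3 (1.31 log units; beyond the scatter), which concerns the exchange of the ring group on the saturated chain carbon.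

Compound 4, `C=C(C)CCC[C@]1(C)C2=CCC[C@](C)(C[C@@H](O)C3=CC(=O)OC3O)[C@H]2CC[C@H]1C`, is the next compound in question. It differs from compound 3 only in this: the two compounds have the same atoms and bonds; at least one stereo element is drawn with a configuration in one of them and without one in the other: 1 of 6 stereo elements differ; a stereocentre at a saturated chain carbon is drawn S in compound 3 and R in compound 4. Going by the values given here, no measured step concerns an inversion at that stereocentre; the step from compound 1 to compound 3 changes the ring group, not the configuration of the carbinol carbon, so it does not bear directly on this change. With nothing in the measured data pointing to a shift in either direction, the expected step of a 1.1-fold higher number from compound 3 to compound 4 (0.04 log units; within the scatter) is one that stays within the scatter. Compound 4 is therefore estimated to give 3500 nM in this assay, with a range from 1400 nM to 9000 nM.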

Compound 4, half-maximal inhibitory concentration: 3800 nM
Compound 4: the middle estimate sits 1.1-fold (0.04 log units) below what was measured; low and high end bracket the measured number.
By their numbers in this assay, from the lowest: compounds 3, 4 and 2 (each within the scatter of the next); then compound 1.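

In this assay, for the compounds shown here, the inversion at the saturated chain carbon, a change no earlier pair of compounds covered, gives a step within the scatter: a 1.2-fold higher number from compound 3 to compound 4 (0.07 log units; within the scatter). The exchange of the ring group, until now seen only on the way to the S configuration of compound 3, also gives a large step beyond the scatter when it arrives at the R configuration, as a 17-fold lower number from compound 1 to compound 4 (1.24 log units; beyond the scatter), so among these compounds it holds for both drawn configurations at that carbon. The side chain can now be compared as well, and a 1.2-fold lower number from compound 2 to compound 4 (0.06 log units; within the scatter) stays within the scatter, so 2-methylprop-2-en-1-yl and 1-methylethenyl on that saturated chain carbon cannot be put in any order here.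

From the compounds shown here alone, whether this stereocentre is truly without effect on the number stays open, and the comparison carries one reservation: the fact that one of compounds 3 and 4 is drawn with a defined configuration and the other without, at the place where they differ It also remains open whether an amine in place of the hydroxyl on the ring group, or a chain longer than 2-methylprop-2-en-1-yl, would move the number beyond the scatter.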